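Aryl swap at the benzylic carbon: projecting compound 4

This account rests on a few compounds, and the source may have more. Where it says the series, first, only, none or still open, it means among the compounds named here.

In a functional assay on HL-60 cells (Homo sapiens) for cytotoxicity, read by MTT assay, with a stated time of 48 h (on this read-out higher numbers stand for weaker inhibition and lower numbers for stronger inhibition), compound 1 `N#Cc1ccc(Cn2c(/C=C3\SC(=S)N(CC(=O)O)C3=O)nc3ccccc32)cc1` gives 7640 nM, the highest of the three numbers in hand. Compound 2 `O=C(O)CN1C(=O)/C(=C/c2nc3ccccc3n2Cc2ccccc2F)SC1=S` gives 210 nM and compound 3 `O=C(O)CN1C(=O)/C(=C/c2nc3ccccc3n2Cc2ccc(F)cc2F)SC1=S` gives 6520 nM. The steps among them are a 36-fold lower number from compound 1 to compound 2 (1.56 log units; beyond the scatter), a 1.2-fold lower number from compound 1 to compound 3 (0.07 log units; within the scatter) and a 31-fold higher number from compound 2 to compound 3 (1.49 log units; beyond the scatter), so one change of the aryl group on the chain carbon bound to the aromatic nitrogen is large while the other stays within the scatter, and the difference between the two fluorinated aryl groups is itself large.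

Compound 4 `COc1cc(Cn2c(/C=C3\SC(=S)N(CC(=O)O)C3=O)nc3ccccc32)cc(OC)c1` differs from compound 1 by 3,5-dimethoxyphenyl in place of 4-cyanophenyl on a saturated chain carbon bound to an aromatic nitrogen. Within the data shown here, no measured step covers this change directly; the two steps at the same place, a 36-fold lower number from compound 1 to compound 2 (1.56 log units; beyond the scatter) and a 1.2-fold lower number from compound 1 to compound 3 (0.07 log units; within the scatter), show only that a change of the aryl group here can be large or negligible, and neither involves a methoxy-bearing ring. With nothing in hand pointing in one direction, the expectation for compound 4 is a number close to that of compound 1, and any step is expected to be small. Compound 4 is expected to give 5000 nM, with a range from 1000 nM to 20000 nM. The step so expected is a 1.5-fold lower number from compound 1 to compound 4 (0.18 log units; within the scatter).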

Compound 4, half-maximal inhibitory concentration: 1410 nM
Estimate against measurement, compound 4: 3.5-fold (0.55 log units) above; low and high end bracket the measured number.
By their numbers in this assay, from the lowest: compound 2; then compound 4; then compounds 3 and 1 (each within the scatter of the next).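

In this assay, the 3,5-dimethoxyphenyl group on the saturated chain carbon bound to an aromatic nitrogen gives a number that lies apart from all three earlier ones: there is a 5.4-fold lower number from compound 1 to compound 4 (0.73 log units; beyond the scatter) and a 4.6-fold lower number from compound 3 to compound 4 (0.67 log units; beyond the scatter), but also a 6.7-fold higher number from compound 2 to compound 4 (0.83 log units; beyond the scatter). Among these compounds, the earlier compounds showed only that an aryl change here could be large or stay within the scatter, whereas these four compounds show an intermediate level at this position, with each step to compound 4 beyond the scatter and none of them large. Compound 3 and compound 4 both carry two ring substituents yet differ beyond the scatter, so the count of substituents alone does not set the number in this small set, and nothing available explains the order of the aryl groups.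

Going by these compounds, whether a single methoxy group on the ring would give the same number as the 3,5-dimethoxyphenyl group remains open. Also open, on these data alone, is how an unsubstituted phenyl, an amine on the ring or a longer chain at the same place would read.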